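The source may report more compounds than this note shows. Statements on the series, on what has been measured and on what is new or still open speak of the compounds shown alone.

Compound 3 `COc1cc(C(=O)O)ccc1OCCCCOc1ccc(C(=O)CC(C)C)c(O)c1C` is the reference point of this note. In an assay on HEK293 cells for positive allosteric modulation of metabotropic glutamate receptor 2 (Rattus norvegicus), read by thallium flux, with a stated time of 2.5 min (on this read-out higher numbers stand for larger maximal responses and lower numbers for smaller maximal responses), compound 3 gives 85.7%. Compound 1 `Cc1cc(C(=O)O)ccc1OCCCCOc1ccc(C(=O)CC(C)C)c(O)c1C` gives 83.9% in this assay, and compound 2 `Cc1c(OCCCCOc2ccc(C(=O)O)cc2F)ccc(C(=O)CC2CCCC2)c1O` gives 83.8%. The three values lie within the usual scatter of one another, so no order among them is claimed. Among the compounds with values here, the one single-point step measured so far, a number 1.8 percentage points higher from compound 1 to compound 3 (within the scatter), left the read-out within the scatter.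

Compound 4 `Cc1c(OCCCCOc2ccc(C(=O)O)cc2F)ccc(C(=O)CC(C)C)c1O` is to be measured in this assay. Its change from compound 3 is fluoro in place of methoxy on an aromatic carbon. Within the data shown here, no measured step exchanges a methoxy for a fluoro, so a number 1.8 percentage points higher from compound 1 to compound 3 (within the scatter) bears only indirectly: the one substituent exchange measured at this position stayed within the scatter. Compound 2 carries a fluoro at the same place, and the value of compound 2, 83.8%, sits with the others. Accordingly no step beyond the scatter is expected for compound 4. Compound 4 is estimated at 84%, with a range from 77% to 91%. The expected step is a number 1.7 percentage points lower from compound 3 to compound 4 (within the scatter).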

Compound 4, largest response reached (reported as percent of maximum), in percent of the reference or control that the assay uses: 85%
Beside the measured number, compound 4's estimate is 1 percentage points below it; the measured number falls inside the stated range.
By their numbers in this assay, from the lowest: compounds 2, 1, 4 and 3 (each within the scatter of the next).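

In this assay, fluoro on the aromatic carbon ortho to a large group and meta to a carboxy group now has direct comparisons with both other substituents: (a number 0.7 percentage points lower from compound 3 to compound 4 (within the scatter)) against methoxy and (a number 1.1 percentage points higher from compound 1 to compound 4 (within the scatter)) against methyl, so none of the three separates from the others. The series also gains its first measured exchange at the other end of the molecule, isopropyl in place of cyclopentyl on a saturated chain carbon bound to a carbonyl carbon (a number 1.2 percentage points higher from compound 2 to compound 4 (within the scatter)), and this too leaves the maximal response unresolved with fluoro in place. No evidence is at hand that accounts for these results.

Every step shown lies within the scatter, so neither place has yet yielded a change that moves the read-out. Going by these compounds, whether an amine or a nitrile on that aromatic carbon, or a longer chain in place of isopropyl, would do so remains open.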